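A Substituent Change Starting From an Assay Limit

The source may hold more compounds than are shown below. What is called first, only, known or untested is meant among the compounds shown, and "the series" means these compounds.

Compound 2 (`Cc1ccc(-c2cncc(/C=C/c3ccc(C(=O)NO)cc3)c2)cc1`) gives > 10000 nM in a functional assay on HCT-116 cells (Homo sapiens) for antiproliferative activity, read by CellTiter-Glo, with a stated time of 72 h (on this read-out lower numbers stand for stronger inhibition and higher numbers for weaker inhibition), and this is a limit of the assay, not a number. Compound 3 (`O=C(NO)c1ccc(/C=C/c2cncc(-c3ccc(C(F)(F)F)cc3)c2)cc1`) gives > 10000 nM in this assay and this too is only a limit. The picture is thus set by the limit of > 10000 nM in this assay, at which 2 of the 3 values shown sit, and little else. Only compound 1 (`O=C(NO)c1ccc(/C=C/c2ccnc(-c3cccc(CO)c3)c2)cc1`) returns a number, with 1700 nM in this assay as its result.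

Compound 4 (`COc1ccc(F)cc1-c1cncc(/C=C/c2ccc(C(=O)NO)cc2)c1`) carries 5-fluoro-2-methoxyphenyl in place of 4-methylphenyl on an aromatic carbon, two atoms from the ring nitrogen. The change counts as follows: 5-fluoro-2-methoxyphenyl in place of 4-methylphenyl on an aromatic carbon for the exchanged group.

Within the data shown here, the only measured step that bears on this change is a step that the two limits leave unreadable from compound 2 to compound 3 and it offers no size to carry over. In this assay no clear step in either direction is therefore expected, and compound 4 should stay close to the limit that holds compound 2. The expected change is an at least 1.1-fold lower number from compound 2 to compound 4 (0.04 log units; that floor lies within the scatter) as an estimate that starts from a limit rather than a number. Compound 4 is estimated at 9000 nM with an expected range from 3000 nM to 25000 nM in this measurement.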

Compound 4, half-maximal inhibitory concentration: 3410 nM
Estimate against measurement, compound 4: 2.6-fold (0.42 log units) above; the measured number falls inside the stated range.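

In this assay, 5-fluoro-2-methoxyphenyl in place of 4-methylphenyl gives an at least 2.9-fold lower number from compound 2 to compound 4 (0.46 log units; beyond the scatter), which shows that the result at this position, two atoms from the ring nitrogen, depends on the group placed there. The earlier step on the same position, trifluoromethyl in place of methyl, cannot be read, so this exchange is the only one among the compounds shown that gives a direction. Its size is a floor and not a full measure, because compound 2 stands at a limit of the assay: the limit of > 10000 nM in this assay, at which 2 of the 4 values shown sit.

The exchange brings in a fluorine and a methoxy group together, so the compounds shown do not tell whether either one alone would give this step or whether both are needed. As far as these compounds go, it also remains open whether an amine or a carboxylic acid on the phenyl ring at this position would lower the number further in this assay.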